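A few compounds are considered here, and "the series" means these few. Any claim that something is new, unique, unknown or untested is made for them only; others in the source may bear on it.

Measured so far:
compound 1, `CC(C)N1CCN(c2ccc3c(c2)oc(=O)n3C(=O)NCCCCc2ccccc2)CC1`: 211 nM in an assay on HEK293 cells for inhibition of acid ceramidase (Homo sapiens), read by fluorescence, with stated times of 10 min and 3 h; on this read-out higher numbers stand for weaker inhibition and lower numbers for stronger inhibition
compound 2, `CC(=O)N1CCc2oc(=O)n(C(=O)NCCCCc3ccccc3)c2C1`: 293 nM in this assay
compound 3, `CCOCCNC(=O)n1c(=O)oc2cc(C3CCN(C)CC3)ccc21`: 1050 nM in this assay

Compound 1 gives the lowest number of the three, but compound 2 lies within the scatter of it; only compound 3 stands beyond the scatter from compound 1. Compound 4, `CCN1CCN(c2ccc3c(c2)oc(=O)n3C(=O)NCCCCc2ccccc2)CC1`, has not been measured. It differs from compound 1 by hydrogen in place of methyl on a saturated chain carbon bound to an amine nitrogen in a ring and a saturated chain carbon. Within the data shown here, no pair of measured compounds isolates a change of this kind, so nothing fixes its effect. Such a small change is expected to leave this assay essentially where compound 1 sits, with no step beyond the scatter in either direction. For compound 4 the estimate is 220 nM, ranging from 110 nM to 450 nM. The expected step is a 1.0-fold higher number from compound 1 to compound 4 (0.02 log units; within the scatter).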

Compound 4, half-maximal inhibitory concentration: 56 nM
Compound 4: middle estimate off by 3.9-fold (0.59 log units), on the high side; measured number below the stated range.
By their numbers in this assay, from the lowest: compound 4; then compounds 1 and 2 (each within the scatter of the next); then compound 3.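

Cutting 4-isopropylpiperazin-1-yl back to 4-ethylpiperazin-1-yl gives a 3.8-fold lower number from compound 1 to compound 4 (0.58 log units; beyond the scatter) in this assay. This place on the amine nitrogen in the ring is therefore sensitive to the loss of a single methyl, a change that adds no hydrogen-bond donor or acceptor and no net charge. No evidence at hand accounts for the step.

As far as these compounds go, how a methyl, a longer chain such as propyl, or a cyclopropyl group would read at this nitrogen remains open. A single step fixes no trend with chain size.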